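The source may report more compounds than this note shows. Statements on the series, on what has been measured and on what is new or still open speak of the compounds shown alone.

Measured compounds in an ADME assay on HepG2 cells (Homo sapiens) for cytotoxicity, read by CellTiter-Glo and resazurin assay, with a stated time of 72 h; a higher number here means that more compound is needed for the effect, a lower number that less compound is needed:
- compound 1 `CC(C)N(Cc1cccc(OCCCCCC(=O)O)c1)C(=O)c1ccc(-c2cccc3ccccc23)cc1` gives > 26000 nM, a limit of the assay, not a number
- compound 2 `Cc1nnc(-c2cccc(-c3ccc(C(=O)N(Cc4cccc(OCCCCCC(=O)O)c4)C(C)C)cc3)c2)o1` gives > 26000 nM, a limit of the assay
- compound 3 `CCOC(=O)CCCCCOc1cccc(CN(C(=O)c2ccc(-c3cccc4ccccc34)cc2)C(C)C)c1` gives > 26000 nM, a limit of the assay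

Compound 3 thus stands at the limit of this assay, and the two other values shown are limits as well; all three sit at the limit of > 26000 nM in this assay, at which 3 of the 3 values shown sit. The step that the two limits leave unreadable from compound 1 to compound 3 is therefore not readable, and neither is a step that the two limits leave unreadable from compound 1 to compound 2.

The next compound, compound 4 `CCOC(=O)CCCCCOc1cccc(CN(C(=O)c2ccc(-c3ccc4c(c3)OCCO4)cc2)C(C)C)c1`, differs from compound 3 in one place: 2,3-dihydro-1,4-benzodioxin-6-yl in place of naphthalen-1-yl on an aromatic carbon. Of the measured steps, a step that the two limits leave unreadable from compound 1 to compound 2 is the one that bears on it, since it also replaces naphthalen-1-yl with another aromatic group on the same aromatic carbon; its size is hidden by the limits. No readable step exists in this series, so no shift beyond the scatter can be expected in either direction in this assay. Compound 4 is expected to remain at the limit of this assay, with an estimated 40000 nM (range 20000 nM to 100000 nM), corresponding to an expected step that the limit leaves unreadable from compound 3 to compound 4.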

Compound 4, half-maximal effective concentration: > 24400 nM
Compound 4: only a limit was reported; the forecaster's own chance of this, stated with the estimate: 85%; the middle value is on the limit's open side.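

In this assay, among these compounds, compound 4 gives > 24400 nM, a limit and not a number; compound 3 is also only a limit, so no step between these compounds can be read. Open remains the concentration at which any compound shown reaches half-maximal effect in this assay, and whether replacing naphthalen-1-yl changes it.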